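The source may hold more compounds than are shown below. What is called first, only, known or untested is meant among the compounds shown, and "the series" means these compounds.

Measured so far in a physicochemical assay for lipophilicity; on this read-out higher numbers stand for higher lipophilicity and lower numbers for lower lipophilicity:

compound 1, `COc1ccc(C(CC(=O)O)CC(=O)NNC(=O)c2cccc(NC(=N)N)c2)cc1`, gives 1
compound 2, `N=C(N)Nc1cccc(C(=O)NNC(=O)CC(CC(=O)O)c2ccc(-c3ccccc3)cc2)c1`, gives 2.8
compound 3, `COc1ccc(C(CC(=O)O)CC(=O)NNC(=O)CCCCNc2ccccn2)cc1`, gives 1.94

Compound 1 and compound 2 share one core and differ in one place: phenyl in place of methoxy on an aromatic carbon. In this assay the step is a number 1.80 log units higher from compound 1 to compound 2 (beyond the scatter).

Compound 3 stands on a different core. The difference between the core of compound 1 and the core of compound 3 is not broken down here. In this assay compound 3 sits second highest of the three, closer to compound 2 than to compound 1.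

Compound 4, `O=C(O)CC(CC(=O)NNC(=O)CCCCNc1ccccn1)c1ccc(-c2ccccc2)cc1`, has not yet been measured in this assay. It relates to compound 3 as compound 2 relates to compound 1: phenyl in place of methoxy on an aromatic carbon. The place is the same in both pairs, so this is the same change, seen twice among the compounds shown.

Going by the values given here, only one measured instance of the change exists, that from compound 1 to compound 2. The expectation for compound 4 rests on that single step and on the value of compound 3. Among the compounds with values here, the step from compound 3 to compound 4 is expected to be a number 1.76 log units higher from compound 3 to compound 4 (beyond the scatter), about the size of the step from compound 1 to compound 2, because a number 1.80 log units higher from compound 1 to compound 2 (beyond the scatter) is the only measured precedent. The core is different, so the transfer is uncertain and the range is kept wide.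

For compound 4 the estimated value in this assay is 3.7, with an expected range from 3.1 to 4.3.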

Compound 4, partition coefficient: 3.74
Compound 4: middle estimate off by 0.04 log units, on the low side, and the stated range covers the measured number.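

In this assay, phenyl in place of methoxy on an aromatic carbon gives a number 1.80 log units higher from compound 3 to compound 4 (beyond the scatter) and, on the other core, a number 1.80 log units higher from compound 1 to compound 2 (beyond the scatter) with the printed size unchanged, so in these two pairs the change carries from one core to the other. With phenyl held in place, a group of 11 heavy atoms (9 carbon, 2 nitrogen; one six-membered aromatic ring with 1 hetero atom) in place of a group of 10 heavy atoms (7 carbon, 3 nitrogen; one six-membered aromatic ring of carbon only), on a carbonyl carbon, gives a number 0.94 log units higher from compound 2 to compound 4 (beyond the scatter) as a further, separate step. Two pairs on two cores in one assay show agreement and not a rule for other cores, and no measurement at hand bears on why the step has this size.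

Open, on these data alone, is whether the same step appears when cyclohexyl or a halogen such as chlorine stands in place of methoxy, or whether it depends on phenyl itself. Going by these compounds alone, also open is whether it holds on a core with a methyl ester in place of the carboxylic acid, or with a longer chain than the one in compound 3.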